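This account rests on a few compounds, and the source may have more. Where it says the series, first, only, none or still open, it means among the compounds named here.

For the measured compounds named here, compound 2 `Cc1cc(C(=O)Nc2cccc(-c3oc4cc(-c5ccc(F)cc5)ccc4c(=O)c3O)c2)ccc1F` gives 5420 nM in a functional assay on HCC1937 cells (Homo sapiens) for antiproliferative activity, read by CCK-8 assay, with a stated time of 72 h (on this read-out higher numbers stand for weaker inhibition and lower numbers for stronger inhibition), the lowest of the two numbers measured so far. Going by the values given here, its nearest neighbour is compound 1 `O=C(Nc1cccc(-c2oc3cc(-c4ccc(F)cc4)ccc3c(=O)c2O)c1)c1ccc(F)cc1`, which gives 14200 nM in this assay; the single step between them, a 2.6-fold lower number from compound 1 to compound 2 (0.42 log units; beyond the scatter), came from a methyl in place of hydrogen on an aromatic carbon.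

Compound 3 `O=C(Nc1cccc(-c2oc3cc(-c4ccc(F)cc4)ccc3c(=O)c2O)c1)c1ccc(-c2ccccc2)cc1` has not yet been measured. It differs from compound 2 by 4-phenylphenyl in place of 4-fluoro-3-methylphenyl on a carbonyl carbon. Among the compounds with values here, no measured step exchanges the whole aryl group on the carbonyl carbon, so only the modest step from compound 1 to compound 2 bears on this change, and it does so indirectly, since compound 3 loses both the methyl and the fluorine that those two compounds carry and gains a second ring instead. The expected step of a 1.5-fold higher number from compound 2 to compound 3 (0.17 log units; within the scatter) is therefore a small rise, within or just beyond the scatter. For compound 3 the estimate in this assay is 8000 nM, with a range from 2500 nM to 25000 nM.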

Compound 3, half-maximal inhibitory concentration: 44100 nM
For compound 3 the middle estimate is 5.5-fold (0.74 log units) below the measured one; measured number outside the range, above it.
By their numbers in this assay, from the lowest: compound 2; then compound 1; then compound 3.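

In this assay, replacing 4-fluoro-3-methylphenyl on the carbonyl carbon with 4-phenylphenyl brings an 8.1-fold higher number from compound 2 to compound 3 (0.91 log units; beyond the scatter), and phenyl in place of fluoro on an aromatic carbon brings a 3.1-fold higher number from compound 1 to compound 3 (0.49 log units; beyond the scatter). Added carbon on this aryl group therefore does not always go with a lower number: the methyl lowered it, the second ring raises it, and compound 3 is the weakest of the three, with both of its steps beyond the scatter. Nothing available gives a reason for this rise.

The compounds shown leave open whether a phenyl placed on the ring of compound 2, with its methyl kept, would raise the number in the same way. They also leave open how an amine, a carboxylic acid or a short alkoxy chain would behave at this place.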